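Ortho-fluoro on the benzyl amide of the chromone series

This account rests on a few compounds, and the source may have more. Where it says the series, first, only, none or still open, it means among the compounds named here.

Compound 1 `COc1ccc2c(=O)c(/C=C/C(=O)Nc3cc(C)ccc3C)coc2c1` gives 15500 nM in a functional assay on A549 cells (Homo sapiens) for inhibition, read by MTT assay, with a stated time of 48 h; a lower number here means a stronger inhibitor, a higher number a weaker inhibitor. Compound 2 `COc1ccc2c(=O)c(/C=C/C(=O)Nc3ccc(Cl)cc3)coc2c1` reaches only the limit > 100000 nM in this assay, as noted under (the limit of > 100000 nM in this assay, at which 1 of the 3 values shown sits). Compound 3 `COc1ccc2c(=O)c(/C=C/C(=O)NCc3ccccc3)coc2c1` gives 11800 nM, the lowest of the two numbers in hand; its nearest neighbour is compound 1, with a 1.3-fold lower number from compound 1 to compound 3 (0.12 log units; within the scatter) lying within the scatter, while an at least 8.4-fold lower number from compound 2 to compound 3 (0.92 log units; beyond the scatter) and an at least 6.4-fold higher number from compound 1 to compound 2 (0.80 log units; beyond the scatter) lie beyond it. Compound 4 `COc1ccc2c(=O)c(/C=C/C(=O)NCc3ccccc3F)coc2c1` differs from compound 3 by fluoro in place of hydrogen on an aromatic carbon. Among the measured compounds shown here, no measured step touches a substituent on the benzyl ring; the steps in hand all exchange the whole group on the amide nitrogen. The step of a 1.2-fold lower number from compound 3 to compound 4 (0.07 log units; within the scatter) is therefore expected to stay within the scatter. Compound 4 is estimated at 10000 nM, in the range 4000 nM to 30000 nM.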

Compound 4, half-maximal inhibitory concentration: > 100000 nM
Compound 4: a limit, no number (the forecaster's own chance of this, stated with the estimate: 10%); middle value at least 10-fold (1.00 log units) away from the limit.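

Fluoro in place of hydrogen on the benzyl ring, ortho to a large group, gives an at least 8.4-fold higher number from compound 3 to compound 4 (0.92 log units; beyond the scatter), so a change on this ring can count for as much as the whole-group exchanges on the amide nitrogen. With 2-fluorobenzyl in place of 2,5-dimethylphenyl, an at least 6.4-fold higher number from compound 1 to compound 4 (0.80 log units; beyond the scatter) shows that a benzyl-type group does not by itself keep the number near that of compound 1. The value of compound 4 is a limit, and the step between the two limit compounds cannot be read: the limit of > 100000 nM in this assay, at which 2 of the 4 values shown sit.

As far as these compounds go, whether this loss belongs to fluoro itself or to any group at this place stays open. An amine or a carboxylic acid on the benzyl ring would test that.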